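A new group on the sulfonyl sulfur

The source may hold more compounds than are shown below. What is called first, only, known or untested is meant among the compounds shown, and "the series" means these compounds.

Measured in an ADME assay on microsomes from liver (Homo sapiens) for pharmacokinetics, read by LC-MS, with a stated time of 60 min, tested at 1 uM; a higher number here means faster removal of the compound, a lower number slower removal:
compound 1 `CC(=O)N1CCC(S(=O)(=O)c2ccc(CNC(=O)N3Cc4ccncc4C3)cc2)CC1` gives 6 mL/min/kg
compound 2 `O=C(NCc1ccc(S(=O)(=O)N2CCC[C@H](O)C2)cc1)N1Cc2ccncc2C1` gives 8 mL/min/kg

Going by the values given here, compound 2 stands level with compound 1, the only other measured compound. Compound 3 `O=C(NCc1ccc(S(=O)(=O)N2CCC(N3CCCC3)CC2)cc1)N1Cc2ccncc2C1` differs from compound 2 in one place, on a sulfonyl sulfur: 4-(pyrrolidin-1-yl)piperidin-1-yl in place of 3-hydroxypiperidin-1-yl on a sulfonyl sulfur. Among the compounds with values here, the one measured step, a 1.3-fold higher number from compound 1 to compound 2 (0.12 log units; within the scatter), also exchanged the group on that sulfur, so it alone bears on this change. No step beyond the scatter is therefore expected, and the estimated step is a 1.4-fold higher number from compound 2 to compound 3 (0.14 log units; within the scatter). For compound 3 the expected clearance is 11 mL/min/kg, with an estimated range of 5 mL/min/kg to 24 mL/min/kg.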

Compound 3, clearance: 6 mL/min/kg
Estimate against measurement, compound 3: 1.8-fold (0.26 log units) above; measured number inside the range.
By their numbers in this assay, from the lowest: compounds 1, 3 and 2 (each within the scatter of the next).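

In this assay the sulfonyl sulfur accepts 4-(pyrrolidin-1-yl)piperidin-1-yl, with two rings and no hydrogen-bond donor, with a 1.3-fold lower number from compound 2 to compound 3 (0.12 log units; within the scatter) and with no change at the digits printed from compound 1 to compound 3 (within the scatter). All three groups shown at this position therefore stand level, so the larger group brings no readable shift in clearance. Nothing shown accounts for this result. From the compounds shown here alone, whether a group carrying a carboxylic acid or an open-chain amine on that sulfur would stay level remains open. Going by these compounds, the effect of changes elsewhere on the shared core also remains open.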